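The compounds below may be only part of what the source reports. "The series", "measured", "known", "first", "only" and "open" are said of these compounds alone.

In a functional assay on SMMC-7721 cells (Homo sapiens) for inhibition, read by MTT assay, with a stated time of 48 h (on this read-out higher numbers stand for weaker inhibition and lower numbers for stronger inhibition), compound 1 (`O=C(Nc1ccccn1)Nc1cc(-c2cncnc2)ccc1OC(F)(F)F`) gives 21600 nM and compound 2 (`O=C(Nc1ccncc1)Nc1cc(-c2cccnc2)ccc1OC(F)(F)F`) gives 42800 nM, two values within the usual scatter of each other. Compound 3 (`COc1ccc(-c2ccc(OC(F)(F)F)c(NC(=O)Nc3ccncc3)c2)cn1`) has no single number: its result stands as "not determined" (no result reported), so it offers no starting value for a step. Compound 4 (`O=C(Nc1ccncc1)Nc1cc(-c2cncnc2)ccc1OC(F)(F)F`) carries pyrimidin-5-yl in place of 6-methoxypyridin-3-yl on an aromatic carbon. Among the measured compounds shown here, no step in this assay can be sized or given a direction from compound 3, so none beyond the scatter is expected relative to the measured compounds, since compound 1, at 21600 nM, also carries pyrimidin-5-yl. Compound 4 is expected at 30000 nM, with an estimated range of 12000 nM to 75000 nM.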

Compound 4, half-maximal inhibitory concentration: 3990 nM
Beside the measured number, compound 4's estimate is 7.5-fold (0.88 log units) above it; measured number outside the range, below it.
By their numbers in this assay, from the lowest: compound 4; then compounds 1 and 2 (each within the scatter of the next).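

In this assay, among the compounds shown here, pyrimidin-5-yl in place of pyridin-3-yl on the aromatic carbon para to a trifluoromethoxy group gives an 11-fold lower number from compound 2 to compound 4 (1.03 log units; beyond the scatter), the first step at this position that can be sized. With pyrimidin-5-yl held, pyridin-4-yl in place of pyridin-2-yl on the amide-type nitrogen gives a 5.4-fold lower number from compound 1 to compound 4 (0.73 log units; beyond the scatter), so the number responds to a change in either place. No available measurement gives a cause for either step.

Compound 3 has no number, so the step from 6-methoxypyridin-3-yl cannot be read. As far as these compounds go, whether an amine or a carboxylic acid on the pyrimidin-5-yl ring would move the number further remains open.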